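The source may report more compounds than this note shows. Statements on the series, on what has been measured and on what is new or still open speak of the compounds shown alone.

Compound 1, `c1ccc(CN[C@H]2CC[C@H](c3c[nH]c4ccccc43)CC2)cc1`, is one of two measured compounds here. In an assay on cell membranes for binding affinity to Adrenergic receptor alpha-1 (Rattus norvegicus), tested at 1 uM (a higher number here means more inhibition at the concentration tested (going by the name of the read-out), a lower number less inhibition), compound 1 gives 64%. Compound 2, `N#Cc1ccc2[nH]cc([C@H]3CC[C@@H](NCc4ccccc4)CC3)c2c1`, carries a nitrile on its shared core and is the other. In this assay compound 2 gives 17%; this is the lower of the two numbers, and compound 1 stands higher by a difference beyond the usual scatter. Within the data shown here, no single-point step between the two measured compounds is available, since they differ in more than one place.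

Compound 3, `N#Cc1ccc2[nH]cc([C@H]3CC[C@H](NCc4ccccc4)CC3)c2c1`, is the compound still to be measured. Its difference from compound 2 is this: the two compounds have the same atoms and bonds and differ only in configuration as drawn: 2 of 2 stereo elements differ (all stereocentres are inverted: mirror images); a stereocentre at a saturated ring carbon is drawn s in compound 2 and r in compound 3; a stereocentre at a saturated ring carbon is drawn s in compound 2 and r in compound 3. The configuration as drawn at the two saturated ring carbons of compound 3 matches that of compound 1, while the nitrile of compound 2 stays. Because compound 1 reaches 64% with that drawn configuration, an upward step from compound 2 to compound 3 is expected, of roughly a number 28 percentage points higher from compound 2 to compound 3 (beyond the scatter), beyond the scatter. The expected inhibition for compound 3 is therefore about 45%, in a range from 15% to 75%.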

Compound 3, a percentage reported as inhibition, at one concentration (the size of the read-out at that concentration, not a potency): 28%
Compound 3: middle estimate off by 17 percentage points, on the high side; measured number inside the range.
By their numbers in this assay, from the lowest: compound 2; then compound 3; then compound 1.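

With the nitrile held in place, inverting both stereocentres at the saturated ring carbons gives a number 11 percentage points higher from compound 2 to compound 3 (beyond the scatter) in this assay, so the drawn configuration matters here, though only modestly. Among these compounds, with the configuration held as drawn in compound 1, cyano in place of hydrogen on an aromatic carbon gives a number 36 percentage points lower from compound 1 to compound 3 (beyond the scatter), a large step that shows the nitrile itself goes with much of the low number of compound 2, a link the earlier compounds could not separate from configuration. The modest step can be assigned to configuration alone, because nothing else changes within that pair: the fact that compounds 2 and 3 differ only in the configuration as drawn

Going by these compounds, whether a chlorine atom or a methoxy group in place of the nitrile would lower the number as far, and whether the mirror image of compound 1 would shift by a similar step, stays open. All three numbers are also readings at a single concentration on one receptor, so they give no potency and say nothing about how these compounds behave at any other target.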